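Aryl Swap on the Sulfonyl Sulfur Toward Compound 3

The source may report more compounds than this note shows. Statements on the series, on what has been measured and on what is new or still open speak of the compounds shown alone.

Compound 2 `CC1CCN(c2c(S(=O)(=O)c3cc(Cl)cc(Cl)c3)cnc3cc(Cl)ccc23)CC1` gives 93% in an assay on isolated protein for displacement of a labelled ligand from metabotropic glutamate receptor 5 (Homo sapiens), with a stated time of 60 min, tested at 1 uM; on this read-out higher numbers stand for more inhibition at the one concentration tested (going by the name of the read-out) and lower numbers for less inhibition. Compound 1 `COc1cccc(S(=O)(=O)c2cnc3cc(Cl)ccc3c2N2CCC(C)CC2)c1` gives 93% in this assay, and the step of no change at the digits printed from compound 1 to compound 2 (within the scatter) shows that exchanging the group on the sulfonyl sulfur left the read-out unchanged within the scatter. Compound 3 `COc1ccc(S(=O)(=O)c2cnc3cc(Cl)ccc3c2N2CCC(C)CC2)cc1OC` differs from compound 2 as follows: 3,4-dimethoxyphenyl in place of 3,5-dichlorophenyl on a sulfonyl sulfur. Among the compounds with values here, only that one measured step bears on this change, and it was flat. For compound 3 the step of a number 5 percentage points lower from compound 2 to compound 3 (within the scatter) is therefore expected to be none beyond the scatter. Compound 3 is estimated at 88%, between 70% and 98%.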

Compound 3, a percentage reported as inhibition, at one concentration (the size of the read-out at that concentration, not a potency): 93%
Compound 3: middle estimate off by 5 percentage points, on the low side; the measured number falls inside the stated range.
By their numbers in this assay, from the lowest: compounds 1, 2 and 3 (each within the scatter of the next).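

In this assay, 3,4-dimethoxyphenyl in place of 3,5-dichlorophenyl on the sulfonyl sulfur gives a flat step (no change at the digits printed from compound 2 to compound 3 (within the scatter)), and methoxy in place of hydrogen on an aromatic carbon gives another (no change at the digits printed from compound 1 to compound 3 (within the scatter)). The sulfonyl sulfur has thus carried three differently substituted phenyl groups, chloro-bearing and methoxy-bearing, with no step beyond the scatter. No supporting data explain this flatness.

Going by these compounds, whether a phenyl ring bearing an amine or a carboxylic acid would behave the same on this sulfur remains open. On these data alone, since all three compounds were read at a single concentration, any difference in potency among them also remains open.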